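Amide aryl swap on the ring nitrogen

This account rests on a few compounds, and the source may have more. Where it says the series, first, only, none or still open, it means among the compounds named here.

Working notes on a short series sharing one core. Compound 1 `CCCCNc1nc(N)nc2c1CN(Cc1ccccc1)CC2` gives 0.06 uM in an assay on HEK293 cells for agonist activity at Toll-like receptor 8 (Homo sapiens), read by a luciferase reporter, with a stated time of 6 h; a higher number here means that more compound is needed for the effect, a lower number that less compound is needed. Among the compounds with values here, compound 2 `CCCCNc1nc(N)nc2c1CN(Cc1cccnc1)CC2` gives 0.13 uM in this assay; the step of a 2.2-fold higher number from compound 1 to compound 2 (0.34 log units; beyond the scatter) is the only single-place change measured so far. Compound 3 `CCCCNc1nc(N)nc2c1CN(C(=O)c1cnc(C)cn1)CC2`, which carries a carbonyl on the amide-type nitrogen in the ring, gives 6.8 uM in this assay, the highest of the three numbers and beyond the scatter from both compound 2 and compound 1.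

Compound 4 `CCCCNc1nc(N)nc2c1CN(C(=O)c1cocn1)CC2` differs from compound 3 by 1,3-oxazol-4-yl in place of 5-methylpyrazin-2-yl on a carbonyl carbon. Within the data shown here, no measured step changes the group on the carbonyl carbon. Among the measured compounds shown here, the only measured exchange of one aromatic ring for another, a 2.2-fold higher number from compound 1 to compound 2 (0.34 log units; beyond the scatter), was modest, and it sat on a saturated chain carbon rather than on a carbonyl, so it bears on this change only loosely. With nothing closer to go on, the step in this assay is expected to be small, in either direction, and may well sit within the scatter. The expected step is a 1.4-fold lower number from compound 3 to compound 4 (0.13 log units; within the scatter). Compound 4 is estimated at 5 uM, with a range of 1.5 uM to 20 uM.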

Compound 4, minimum effective concentration: 0.2 uM
Estimate against measurement, compound 4: 25-fold (1.40 log units) above; measured number below the stated range.
By their numbers in this assay, from the lowest: compound 1; then compounds 2 and 4 (each within the scatter of the next); then compound 3.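

On the carbonyl carbon bound to the amide-type nitrogen in a ring, the attached group matters strongly in this assay: 1,3-oxazol-4-yl in place of 5-methylpyrazin-2-yl gives a 34-fold lower number from compound 3 to compound 4 (1.53 log units; beyond the scatter), so the carbonyl on this nitrogen does not by itself fix the high number seen for compound 3. The amide can also match a ring amine, as a 1.5-fold higher number from compound 2 to compound 4 (0.19 log units; within the scatter) is within the scatter, although a 3.3-fold higher number from compound 1 to compound 4 (0.52 log units; beyond the scatter) remains a modest step beyond it. Nothing available explains the large difference between the two groups on the carbonyl carbon.

This exchange changes the ring size, the ring atoms and the methyl together, and a pyrazin-2-yl without the methyl or a methyl-bearing 1,3-oxazol-4-yl on the same carbonyl carbon would separate these changes. Going by these compounds, the role of the carbonyl itself also stays open, and a (1,3-oxazol-4-yl)methyl on the ring nitrogen would test it directly.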